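This account rests on a few compounds, and the source may have more. Where it says the series, first, only, none or still open, it means among the compounds named here.

Working notes on the series.

Compound 1 `CC[C@@H]1C(=O)N(C)c2cnc(-n3ccc4cc(F)ccc43)nc2N1C1CCCC1` gives 46500 nM in a functional assay on NCI-H1975 cells (Homo sapiens) for antiproliferative activity, read by CCK-8 assay, with a stated time of 72 h (a lower number here means a stronger inhibitor of growth, a higher number a weaker inhibitor of growth), the highest of the three numbers recorded so far. Compound 2 `CC[C@@H]1C(=O)N(C)c2cnc(Nc3ccc(S(=O)(=O)NC4CCCC4)cc3)nc2N1C1CCCC1` gives 1710 nM in this assay, and compound 3 `CCC1C(=O)N(C)c2cnc(-n3ccc4cc(C(=O)NCC(C)C)ccc43)nc2N1c1ccn(C)n1` gives 10200 nM; both sit well below compound 1, beyond the scatter, compound 2 furthest away and compound 3 nearest.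

Compound 4 `CCNC(=O)c1ccc2c(ccn2-c2ncc3c(n2)N(C2CCCC2)[C@H](CC)C(=O)N3C)c1` has not been measured in this assay. It differs from compound 1 in one place: ethylcarbamoyl in place of fluoro on an aromatic carbon. For the measured compounds named here, compound 3 also carries a carbamoyl substituent on the shared core, though with a different group on the other ring nitrogen, so no single measured step isolates this change.

Compound 4 is expected to give 8000 nM in this assay, with a likely range of 2000 nM to 30000 nM. The expected step of a 5.8-fold lower number from compound 1 to compound 4 (0.76 log units; beyond the scatter) is toward a lower number, beyond the scatter, because compound 3 with its carbamoyl gives 10200 nM while compound 1 gives 46500 nM.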

Compound 4, concentration for 50% growth inhibition: 882 nM
Beside the measured number, compound 4's estimate is 9.1-fold (0.96 log units) above it; measured number below the stated range.
By their numbers in this assay, from the lowest: compounds 4 and 2 (each within the scatter of the next); then compound 3; then compound 1.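

In this assay, for the compounds shown here, the aromatic carbon carrying fluoro in compound 1 proves to be a strong lever on growth inhibition: ethylcarbamoyl in its place gives a 53-fold lower number from compound 1 to compound 4 (1.72 log units; beyond the scatter), the first step that isolates a single change. The position therefore accepts a group of five heavy atoms in place of a single fluorine, and the number falls rather than rises, but this one step changes size, the hydrogen-bond donor and the hydrogen-bond acceptor together, so it cannot assign the gain to any one of them. No measurement available here accounts for the size of this step.

The compounds shown leave open whether the amide hydrogen matters, which a dimethylcarbamoyl group would test. Also open, from the compounds shown here alone, is how an unsubstituted carbamoyl, a longer chain on the amide nitrogen or a carboxylic acid would behave on the same carbon.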